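Replacing Acetoxy with 3-(Benzyloxy)propyl in Compound 3

This account rests on a few compounds, and the source may have more. Where it says the series, first, only, none or still open, it means among the compounds named here.

In an ADME assay on HOS cells (Homo sapiens) for cytotoxicity, read by luminescence and ATP content, with a stated time of 48 h (on this read-out higher numbers stand for lower toxicity in this test and lower numbers for higher toxicity in this test), compound 1 `COc1ccc2c(O)c(C(=O)NCc3ccc(F)cc3F)c(=O)n(O)c2n1` gives 12000 nM as a measured number. Compound 2 `CC(=O)OCCCc1cnc2c(c1)c(N)c(C(=O)NCc1ccc(F)cc1F)c(=O)n2O` reads > 250000 nM and this is a limit of the assay, not a number. Compound 2 therefore stands at that limit, while only compound 1 has a measured number. The change 3-(benzyloxy)propyl in place of acetoxy on a saturated chain carbon, three bonds along the chain from an aromatic carbon puts 3-(benzyloxy)propyl in place of acetoxy on a saturated chain carbon, three bonds along the chain from an aromatic carbon, giving compound 3 `Nc1c(C(=O)NCc2ccc(F)cc2F)c(=O)n(O)c2ncc(CCCCCCOCc3ccccc3)cc12` from compound 2. Within the data shown here, no measured pair shows this change, so any expectation is loose. Compound 1 at 12000 nM shows that the shared core can give a measured number, so a lower number in this assay is expected. The expected at least 6.2-fold lower number from compound 2 to compound 3 (0.79 log units; beyond the scatter) is a clear move toward higher toxicity, beyond the scatter. The estimate for compound 3 is 40000 nM with a range from 8000 nM to 200000 nM as the estimated span.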

Compound 3, half-maximal cytotoxic concentration: 14400 nM
The estimate for compound 3 lay 2.8-fold (0.44 log units) above the measured number; low and high end bracket the measured number.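

In this assay, putting 3-(benzyloxy)propyl in place of acetoxy on a saturated chain carbon, three bonds along the chain from an aromatic carbon, gives an at least 17-fold lower number from compound 2 to compound 3 (1.23 log units; beyond the scatter). This shows that the read-out responds to a change at this position, and that compound 3 gives a measured number, 14400 nM, at this position. The step is bounded on one side only, as it starts from a limit of the assay and not from a number: the limit of > 250000 nM in this assay, at which 1 of the 3 values shown sits.

The compounds shown leave open which part of the entering group goes with the step, the six-membered aromatic ring or the longer chain with its oxygen. A plain alkyl chain, a free hydroxyl or an amine at this position would help to separate these parts.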